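Cytotoxicity series: hybrid of compounds 1 and 3

The compounds below may be only part of what the source reports. "The series", "measured", "known", "first", "only" and "open" are said of these compounds alone.

Measured so far in an ADME assay on HepG2 cells (Homo sapiens) for cytotoxicity, read by CellTiter-Glo and resazurin assay, with a stated time of 72 h; on this read-out higher numbers stand for an effect only at larger amounts of compound and lower numbers for an effect already at smaller amounts:
- Compound 1, `CC(C)N(Cc1cccc(OCCCCCC(=O)O)c1)C(=O)c1ccc(-c2cccc(OC(F)(F)F)c2)cc1`, gives > 26000 nM, a limit of the assay rather than a number.
- Compound 2, `CCOC(=O)CCCCCOc1cccc(CN(C(=O)c2ccc(-c3cccnc3)cc2)C(C)C)c1`, gives > 26000 nM, again a limit.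
- Compound 3, `CCOC(=O)CCCCCOc1cccc(CN(C(=O)c2ccc(-c3cccc(-c4nnc(C)o4)c3)cc2)C(C)C)c1`, gives > 26000 nM, also a limit.

Compound 3 therefore stands only at a limit in this assay, as do the other two values shown; all three sit at the limit of > 26000 nM in this assay, at which 3 of the 3 values shown sit. Going by the values given here, the one comparison that differs in a single place, from compound 2 to compound 3, reads a step that the two limits leave unreadable from compound 2 to compound 3, so its size is not readable.

Compound 4, `CCOC(=O)CCCCCOc1cccc(CN(C(=O)c2ccc(-c3cccc(OC(F)(F)F)c3)cc2)C(C)C)c1`, has not yet been measured. The change from compound 3 is trifluoromethoxy in place of 5-methyl-1,3,4-oxadiazol-2-yl on an aromatic carbon. Among the compounds with values here, the new group is the one carried by compound 1, while the chain end is that of compounds 2 and 3. Within the data shown here, no measured step bears a readable size on this change; the only guide is that every value shown is a limit. The step from compound 3 to compound 4 in this assay is accordingly expected to be a step that the limit leaves unreadable from compound 3 to compound 4, that is, none beyond the scatter. For compound 4 the expected value in this assay is 30000 nM, within 15000 nM to 60000 nM, most likely reported again as a limit.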

Compound 4, half-maximal effective concentration: > 26000 nM
Compound 4 was reported as a limit (the forecaster's own chance of this, stated with the estimate: 85%); the middle value lies beyond the limit too.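

The steps from compounds 1, 2 and 3 to compound 4 cannot be read in this assay, because each value is a limit and not a number: the limit of > 26000 nM in this assay, at which 4 of the 4 values shown sit.

The compounds shown leave open whether the acid and ethyl ester chain ends, or the three aryl groups, differ at all in this assay.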